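Amide substituent variation at the carbonyl carbon

The source may hold more compounds than are shown below. What is called first, only, known or untested is meant among the compounds shown, and "the series" means these compounds.

Measured compounds:
compound 1 `Cc1cc(S(=O)(=O)N2C=CNC(=O)[C@H]2CC(=O)N2CCC[C@H](N3CCCC3)C2)c(C)cc1Cl` – 38 nM
compound 2 `Cc1cc(S(=O)(=O)N2C=CNC(=O)[C@H]2CC(=O)N2CCCCC(N(C)C)CC2)c(C)cc1Cl` – 4.75 nM

Compound 2 stands as the lower of the two numbers in an in vitro functional assay on cells for antagonist activity at B1 bradykinin receptor (Homo sapiens), read by luminescence and calcium flux, with a stated time of 2 h; a higher number here means a weaker inhibitor, a lower number a stronger inhibitor; compound 1 sits at 38 nM, and the step from it, an 8.0-fold lower number from compound 1 to compound 2 (0.90 log units; beyond the scatter), is beyond the scatter.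

Compound 3 `Cc1cc(S(=O)(=O)N2C=CNC(=O)[C@H]2CC(=O)N2C[C@H]3CN(C)C[C@H]3C2)c(C)cc1Cl` carries a group of 9 heavy atoms (7 carbon, 2 nitrogen; 2 five-membered non-aromatic rings with 1 hetero atom each) in place of a group of 11 heavy atoms (9 carbon, 2 nitrogen; one eight-membered non-aromatic ring with 1 hetero atom), on a carbonyl carbon. Going by the values given here, the only step measured so far, an 8.0-fold lower number from compound 1 to compound 2 (0.90 log units; beyond the scatter), concerns this same position and shows that exchanging the amine-bearing ring attached at the carbonyl carbon can move the number by a large amount. Nothing measured distinguishes the two five-membered rings now entering from the eight-membered ring that leaves, so the direction is open. The expectation is therefore a step of modest size, more likely towards a higher number than a lower one, estimated as a 2.5-fold higher number from compound 2 to compound 3 (0.40 log units; beyond the scatter). Compound 3 is expected to give 12 nM in this assay, with a range from 2.5 nM to 60 nM.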

Compound 3, half-maximal inhibitory concentration: 136 nM
Beside the measured number, compound 3's estimate is 11-fold (1.05 log units) below it; the measured number lies above the stated range.
By their numbers in this assay, from the lowest: compound 2; then compound 1; then compound 3.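

In this assay, going by these compounds alone, the group with 2 five-membered non-aromatic rings on the carbonyl carbon gives a 29-fold higher number from compound 2 to compound 3 (1.46 log units; beyond the scatter), a large step where the only earlier step at this position was modest. It also gives a 3.6-fold higher number from compound 1 to compound 3 (0.55 log units; beyond the scatter), so compound 3 is the weakest inhibitor of the three and neither of the 11-heavy-atom groups is matched by this 9-heavy-atom group. No supporting measurement bears on why the number rises with this change.

Ring size, ring number, heavy-atom count and the 2 defined stereocentres all change together in this exchange, so the compounds shown cannot assign the rise to any one of these features. On these data alone, it remains open whether a seven-membered non-aromatic ring carrying a dimethylamino group on the same carbonyl carbon would stay close to compound 2 or move towards compound 3, and whether another stereoisomer of the entering group would give a different number.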